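The source may hold more compounds than are shown below. What is called first, only, known or untested is meant among the compounds shown, and "the series" means these compounds.

Measured so far:
Compound 1 `Cn1nc(Cc2nnc(SCCCCCCCC(=O)Nc3ccc(Cl)cc3Cl)n2CCC=O)c2ccccc2c1=O` — in an assay on 32D cells for inhibition of interleukin-15 (Mus musculus), read by resazurin assay, with stated times of 30 min and 2.5 days, in the presence of a further agent that is not named here (a higher number here means a weaker inhibitor, a lower number a stronger inhibitor), compound 1 gives 5500 nM.
Compound 2 `Cn1nc(Cc2nnc(SCCCCCCCC(=O)Nc3ccc(Cl)cc3Cl)n2CCCO)c2ccccc2c1=O` — in this assay compound 2 reaches only a limit, > 30000 nM.
Compound 3 `Cn1c(Cc2nn(CCCO)c(=O)c3ccccc23)nnc1SCCCCCCCC(=O)Nc1ccc(Cl)cc1Cl` — in this assay compound 3 reaches only a limit, > 30000 nM.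

Compound 1 and compound 2 share one core and differ in a single place: formyl in place of hydroxymethyl on a saturated chain carbon, two bonds along the chain from an aromatic nitrogen. That change gave an at least 5.4-fold lower number from compound 2 to compound 1 (0.73 log units; beyond the scatter), a step read against a starting value that is itself a limit (the limit of > 30000 nM in this assay, at which 2 of the 3 values shown sit).

Compound 3 holds the same atoms as compound 2 joined differently; the difference between the two cores is not broken down here.

Compound 4 `Cn1c(Cc2nn(CCC=O)c(=O)c3ccccc23)nnc1SCCCCCCCC(=O)Nc1ccc(Cl)cc1Cl` stands to compound 3 as compound 1 stands to compound 2: formyl in place of hydroxymethyl on a saturated chain carbon, two bonds along the chain from an aromatic nitrogen. The place is the same in wording for both pairs, so this is the same kind of change on the other core.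

The step expected from compound 3 to compound 4 in this assay is an at least 2.5-fold lower number from compound 3 to compound 4 (0.39 log units; beyond the scatter), set beside an at least 5.4-fold lower number from compound 2 to compound 1 (0.73 log units; beyond the scatter) and resting on that single measured pair, with the added uncertainty that compound 3 starts at a limit (the limit of > 30000 nM in this assay, at which 2 of the 3 values shown sit). Compound 4 is therefore estimated at 12000 nM, expected to fall between 3000 nM and 40000 nM.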

Compound 4, half-maximal inhibitory concentration: 11700 nM
Compound 4: the middle estimate sits 1.0-fold (0.01 log units) above what was measured, within the range that was stated.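

In this assay, formyl in place of hydroxymethyl again gives a lower number, an at least 2.5-fold lower number from compound 3 to compound 4 (0.40 log units; beyond the scatter), so the direction seen on the core of compound 1 also appears on the core of compound 4. This shows that the change carries over in direction between these two cores, but it does not show that it carries over in size: the same change on two cores in this assay, an at least 5.4-fold lower number (0.73 log units; beyond the scatter) from compound 2 to compound 1 and an at least 2.5-fold lower number (0.40 log units; beyond the scatter) from compound 3 to compound 4; the limit leaves it open whether they differ Each step starts from a limit, so each gives only a minimum size, and two pairs support no rule beyond these four compounds: the limit of > 30000 nM in this assay, at which 2 of the 4 values shown sit.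

The compounds shown leave open whether the lower number is specific to the formyl group or would also appear with a carboxylic acid or an amine at the end of the same chain. As far as these compounds go, it also remains open how a longer chain carrying the formyl group would read in this assay on either core.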